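A few compounds are considered here, and "the series" means these few. Any claim that something is new, unique, unknown or untested is made for them only; others in the source may bear on it.

Compound 1 `COc1ccc(NC(=O)Nc2ccc(Nc3ncnc4c3OCCN4)cc2)cc1` gives 824 nM in an assay on isolated protein for inhibition of proto-oncogene tyrosine-protein kinase receptor Ret variant V804M (Homo sapiens), read by 33P incorporation, with stated times of 15 min and 40 min; on this read-out lower numbers stand for stronger inhibition and higher numbers for weaker inhibition. Compound 2 `COc1cccc(NC(=O)Nc2ccc(Nc3ncnc4c3OCCN4)cc2)c1` gives 5290 nM. Compound 3 `Cc1ccc(F)c(NC(=O)Nc2ccc(Nc3ncnc4c3OCCN4)cc2)c1` gives 5110 nM.

Compound 3 stands second highest of the three numbers: a 6.2-fold higher number from compound 1 to compound 3 (0.79 log units; beyond the scatter), while a 1.0-fold lower number from compound 2 to compound 3 (0.02 log units; within the scatter). Compound 4 `Cc1cc(C)cc(NC(=O)Nc2ccc(Nc3ncnc4c3OCCN4)cc2)c1` carries 3,5-dimethylphenyl in place of 2-fluoro-5-methylphenyl on an amide-type nitrogen. For the measured compounds named here, no measured step changes the group in this way; the steps seen only show that a 4-methoxyphenyl gives a lower number than either of the other two groups, and that 3-methoxyphenyl and 2-fluoro-5-methylphenyl sit together. For a group that again lacks the 4-methoxy substituent, compound 4 is therefore expected to stay near compound 3, with a 1.1-fold lower number from compound 3 to compound 4 (0.06 log units; within the scatter) within the scatter. The estimate for compound 4 is 4500 nM, in the range 1500 nM to 13000 nM.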

Compound 4, half-maximal inhibitory concentration: 971 nM
For compound 4 the middle estimate is 4.6-fold (0.67 log units) above the measured one; the whole stated range lies above it.
By their numbers in this assay, from the lowest: compounds 1 and 4 (each within the scatter of the next); then compounds 3 and 2 (each within the scatter of the next).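

At this position, a low number does not require the 4-methoxyphenyl group: 3,5-dimethylphenyl gives a 5.3-fold lower number from compound 3 to compound 4 (0.72 log units; beyond the scatter) and a 5.4-fold lower number from compound 2 to compound 4 (0.74 log units; beyond the scatter), while a 1.2-fold higher number from compound 1 to compound 4 (0.07 log units; within the scatter). A group of carbon only can therefore match 4-methoxyphenyl, and a small change in the aryl group can move the number well beyond the scatter. No measured evidence accounts for these differences.

The compounds shown leave open which part of the change from 2-fluoro-5-methylphenyl to 3,5-dimethylphenyl matters. They also leave open whether a plain phenyl or a chlorophenyl group would give a similarly low number.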